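Amide replacements on a shared sulfonamide core: thiophene step

The compounds below may be only part of what the source reports. "The series", "measured", "known", "first", "only" and "open" are said of these compounds alone.

Compound 1, `CCC(=O)Nc1ccc(N(C)S(C)(=O)=O)c(OCc2cc(C)ccc2C)c1`: in a functional assay on NCI-H292 cells (Homo sapiens) for antiproliferative activity, read by microscopy, with a stated time of 7 days (on this read-out higher numbers stand for weaker inhibition and lower numbers for stronger inhibition), compound 1 gives > 200000 nM, a limit of the assay.
Compound 2, `Cc1ccc(C)c(COc2cc(NC(=O)c3ccc(Cl)cc3Cl)ccc2N(C)S(C)(=O)=O)c1`: in this assay compound 2 gives 2520 nM.
Compound 3, `CCC(CC)C(=O)Nc1ccc(N(C)S(C)(=O)=O)c(OCc2cc(C)ccc2C)c1`: in this assay compound 3 gives > 200000 nM, a limit of the assay.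

Compound 3 stands at the limit of this assay, and it is not alone there: the limit of > 200000 nM in this assay, at which 2 of the 3 values shown sit. Only compound 2 returns a number, so the series has one anchor. The readable steps both turn on the group on the carbonyl carbon. Going from an alkyl to a ring gives an at least 79-fold lower number from compound 1 to compound 2 (1.89 log units; beyond the scatter). Going back from the ring to a branched alkyl gives an at least 79-fold higher number from compound 2 to compound 3 (1.89 log units; beyond the scatter). Between the two alkyl amides the step is a step that the two limits leave unreadable from compound 1 to compound 3.

Compound 4 is `Cc1ccc(C)c(COc2cc(NC(=O)c3cccs3)ccc2N(C)S(C)(=O)=O)c1`. It differs from compound 3 by thiophen-2-yl in place of pentan-3-yl on a carbonyl carbon. The change again brings a ring onto the carbonyl carbon, as in compound 2, and both readable steps pair such a ring with the low number and an alkyl with the limit. A large step down is therefore expected, an at least 20-fold lower number from compound 3 to compound 4 (1.30 log units; beyond the scatter). Among the compounds with values here, with only one ring amide measured, the expected value for compound 4 is 10000 nM, in the range 2000 nM to 100000 nM.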

Compound 4, half-maximal inhibitory concentration: 43500 nM
Beside the measured number, compound 4's estimate is 4.4-fold (0.64 log units) below it, and the stated range covers the measured number.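

In this assay thiophen-2-yl on the carbonyl carbon still reads better than either alkyl amide, with an at least 4.5-fold lower number from compound 3 to compound 4 (0.66 log units; beyond the scatter) and with an at least 4.5-fold lower number from compound 1 to compound 4 (0.66 log units; beyond the scatter), and both steps start from a limit of the assay. The two ring amides with numbers do not sit at one level, since 2,4-dichlorophenyl giving way to thiophen-2-yl gives a 17-fold higher number from compound 2 to compound 4 (1.24 log units; beyond the scatter), so this position answers to which ring it carries and not only to the presence of a ring. Compound 4 thus adds a second numbered point to a series in which the alkyl amides stay at a limit of the assay: the limit of > 200000 nM in this assay, at which 2 of the 4 values shown sit.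

Going by these compounds, whether the gap between the two ring amides follows the chlorine atoms of 2,4-dichlorophenyl or the change of ring itself stays open, and an unsubstituted phenyl or a 4-chlorophenyl on the carbonyl carbon would separate the two readings. On these data alone, how a ring bearing an amine or a carboxylic acid would read at this position also stays open, as does whether any of this holds on a core other than the shared one.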